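Trifluoromethyl for azido on the benzyl ring of compound 2

A few compounds are considered here, and "the series" means these few. Any claim that something is new, unique, unknown or untested is made for them only; others in the source may bear on it.

Compound 1 `COc1cc(N(Cc2ccc(C)cc2)C(=O)CSc2nc3ccccc3s2)cc(OC)c1OC`: in a functional assay on HCT-116 cells (Homo sapiens) for antiproliferative activity, read by MTT assay, with a stated time of 48 h (on this read-out lower numbers stand for stronger inhibition and higher numbers for weaker inhibition), compound 1 gives only the assay limit > 80000 nM.
Compound 2 `COc1ccc(CN(C(=O)CSc2nc3ccccc3s2)c2cc(OC)c(OC)c(OC)c2)cc1N=[N+]=[N-]`: in this assay compound 2 gives 2860 nM.
Compound 3 `COc1ccc(CN(C(=O)CSc2nc3ccccc3s2)c2cc(OC)c(OC)c(OC)c2)cc1OC`: in this assay compound 3 gives 33900 nM.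

Compound 2 holds the lowest of the two numbers; its nearest neighbour is compound 3, with a 12-fold higher number from compound 2 to compound 3 (1.07 log units; beyond the scatter). Compound 4 `COc1ccc(CN(C(=O)CSc2nc3ccccc3s2)c2cc(OC)c(OC)c(OC)c2)cc1C(F)(F)F` differs from compound 2 by trifluoromethyl in place of azido on an aromatic carbon. The step that bears most directly on it is the exchange at the same aromatic carbon, a 12-fold higher number from compound 2 to compound 3 (1.07 log units; beyond the scatter), a large rise. The steps of an at least 27-fold lower number from compound 1 to compound 2 (1.44 log units; beyond the scatter) and an at least 2.3-fold lower number from compound 1 to compound 3 (0.37 log units; beyond the scatter) rest on the limit of > 80000 nM in this assay, at which 1 of the 3 values shown sits, for compound 1 and give only bounds. Trifluoromethyl is not methoxy, and the rise is expected to be smaller. Compound 4 is therefore expected at 10000 nM (range 2500 nM to 40000 nM), an expected step of a 3.5-fold higher number from compound 2 to compound 4 (0.54 log units; beyond the scatter).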

Compound 4, half-maximal inhibitory concentration: > 80000 nM
Compound 4 ended at the assay's limit (the forecaster's own chance of this, stated with the estimate: 5%); at least 8.0-fold (0.90 log units) between middle value and limit.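

In this assay, the number at this aromatic carbon proved highly dependent on the group placed there: trifluoromethyl in place of azido gave an at least 27-fold higher number from compound 2 to compound 4 (1.44 log units; beyond the scatter), and trifluoromethyl in place of methoxy gave an at least 2.3-fold higher number from compound 3 to compound 4 (0.37 log units; beyond the scatter). Neither exchange for trifluoromethyl kept the activity of compound 2 or of compound 3. Both steps are bounds only, and the step involving compound 1 and compound 4 cannot be read: the limit of > 80000 nM in this assay, at which 2 of the 4 values shown sit.

Going by these compounds, how far the true number of compound 4 lies past the limit remains open. So does whether an amine or a nitrile at this carbon would match compound 2.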